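Replacing a Saturated Ring with a Conjugated Diene

The source may report more compounds than this note shows. Statements on the series, on what has been measured and on what is new or still open speak of the compounds shown alone.

Compound 1 `O=C(O)CCCC(=O)OCCc1c(-c2ccccc2Cl)c2cc(Cl)ccc2[nH]c1=O`: 110000 nM
Compound 2 `O=C(OCCc1c(-c2ccccc2Cl)c2cc(Cl)ccc2[nH]c1=O)C1CCCCC1`: 38000 nM
Compound 3 `COc1ccc(/C=C/C(=O)OCCc2c(-c3ccccc3Cl)c3cc(Cl)ccc3[nH]c2=O)cc1`: the assay reports only a limit, > 1200000 nM

In an ADME assay on HepG2 2.2.15 cells (Homo sapiens) for cytotoxicity (on this read-out lower numbers stand for higher toxicity in this test and higher numbers for lower toxicity in this test), compound 2 gives 38000 nM, the lowest number among the values that are actual numbers. Its nearest neighbour is compound 1 with 110000 nM, so that a 2.9-fold lower number from compound 1 to compound 2 (0.46 log units; beyond the scatter). Compound 3 stands apart: for compound 3 the assay reports a limit, > 1200000 nM, not a number. Compound 4 `C/C=C/C=C/C(=O)OCCc1c(-c2ccccc2Cl)c2cc(Cl)ccc2[nH]c1=O` differs from compound 2 in one place: penta-1,3-dien-1-yl in place of cyclohexyl on a carbonyl carbon. The measured steps that bear on this exchange are those that likewise replace a saturated or acid-bearing group with an unsaturated one on the same carbonyl carbon: an at least 31-fold higher number from compound 2 to compound 3 (1.49 log units; beyond the scatter) and an at least 10-fold higher number from compound 1 to compound 3 (1.03 log units; beyond the scatter), both resting on (the limit of > 1200000 nM in this assay, at which 1 of the 3 values shown sits). Both steps were large and pointed upward. The penta-1,3-dien-1-yl group shares the non-aromatic double bonds with that exchange but lacks its aromatic ring, so a step upward, of middling size, is expected. Compound 4 is therefore estimated at 150000 nM, with a range from 40000 nM to 600000 nM. This corresponds to an expected 3.9-fold higher number from compound 2 to compound 4 (0.60 log units; beyond the scatter).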

Compound 4, half-maximal cytotoxic concentration: 440000 nM
Estimate against measurement, compound 4: 2.9-fold (0.47 log units) below, and the stated range covers the measured number.
By their numbers in this assay, from the lowest: compound 2; then compound 1; then compound 4. At a limit, above all of these: compound 3.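

In this assay, a group with no aromatic ring is enough for a large step on this carbonyl carbon, as penta-1,3-dien-1-yl replaces cyclohexyl: a 12-fold higher number from compound 2 to compound 4 (1.06 log units; beyond the scatter). The same group also gives a modest step over the acid-bearing chain: a 4.0-fold higher number from compound 1 to compound 4 (0.60 log units; beyond the scatter). Compound 3 has only a limit, > 1200000 nM, so an at least 2.7-fold lower number from compound 3 to compound 4 (0.43 log units; beyond the scatter) bounds the exchange of 4-methoxyphenyl for prop-1-en-1-yl without fixing its size: the limit of > 1200000 nM in this assay, at which 1 of the 4 values shown sits.

Going by these compounds, it remains open whether the double bonds or the loss of the ring carries the rise, a question that a saturated pentyl chain on the same carbonyl carbon would address. On these data alone, how an amine-bearing chain at this place would read in this assay is also open.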